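A few compounds are considered here, and "the series" means these few. Any claim that something is new, unique, unknown or untested is made for them only; others in the source may bear on it.

Working notes on the series. Going by the values given here, the three compounds measured so far share the core of compound 1 `CC(C)(C)c1nc(N)ncc1-c1ccccc1` and differ only in the group carried on one aromatic carbon of that core. In a functional assay on the whole organism for inhibition, with Rattus norvegicus as the target, with stated times of 1 h and 3.5 h, at a dose of 100 mg/kg by the oral route (a higher number here means more inhibition at the dose given (going by the name of the read-out), a lower number less inhibition), compound 1 gives 46%, the highest of the three numbers in hand. Compound 2 `Cc1ncc(-c2ccccc2)c(C(C)(C)C)n1` gives 22%, and compound 3 `CC(=O)N(C(C)=O)c1ncc(-c2ccccc2)c(C(C)(C)C)n1` gives 22%. Replacing the amino costs in both cases: a number 24 percentage points lower from compound 1 to compound 2 (beyond the scatter), and a number 24 percentage points lower from compound 1 to compound 3 (beyond the scatter); between the two replacements there is no change at the digits printed from compound 2 to compound 3 (within the scatter).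

Compound 4 `CC(C)(C)c1nc(N)ncc1-c1ccc(Cl)cc1` has not yet been measured. It differs from compound 1 in one place: chloro in place of hydrogen on an aromatic carbon. The amino of compound 1, which carries the top number, is kept unchanged. Among the compounds with values here, the change sits on the six-membered aromatic ring of carbon only, where no measured step has been taken; all three measured steps act on the amino carbon, so none of them bears directly on this substitution, and the measured steps give no size for it. The expectation therefore rests on compound 1 alone and is for no step beyond the scatter, expected as a number 2 percentage points higher from compound 1 to compound 4 (within the scatter). Compound 4 is thus expected to give 48%, with a range from 25% to 70%.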

Compound 4, a percentage reported as inhibition, in the whole organism at one dose (the size of the read-out at that dose, not a potency): 25%
Compound 4: middle estimate off by 23 percentage points, on the high side, within the range that was stated.
By their numbers in this assay, from the lowest: compounds 2, 3 and 4 (each within the scatter of the next); then compound 1.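

Going by these compounds alone, the chloro gives the first measured step on the six-membered aromatic ring of carbon only: in this assay, with the amino kept, there is a number 21 percentage points lower from compound 1 to compound 4 (beyond the scatter). This position, para to a large group, is therefore not indifferent to substitution, and a change away from the amino carbon can cost beyond the scatter, leaving compound 1 the highest of the four compounds. Nothing measured on these compounds bears on why the number falls with this change.

The compounds shown leave open whether the fall belongs to chloro itself or to any group at this place, which a fluoro, a methyl or a methoxy on the same carbon would help to separate, and whether a chloro elsewhere on the same ring would give a similar step. They also leave open whether the chloro would lower the number in the same way on a core carrying methyl or diacetylamino in place of the amino, and a read-out at a single dose cannot say how the step would look at other doses.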